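The source may hold more compounds than are shown below. What is called first, only, known or untested is meant among the compounds shown, and "the series" means these compounds.

Working notes on the series

Compound 1 `COc1ccccc1C(=O)/C=C/c1ccc2c(c1)B(O)OC2` and compound 2 `COc1cccc(C(=O)/C=C/c2ccc3c(c2)B(O)OC3)c1` share the same atoms, joined differently; the difference between the two cores is not broken down here. In a toxicity assay on WI-38 cells (Homo sapiens) for cytotoxicity, read by MTT assay, with a stated time of 48 h (on this read-out lower numbers stand for stronger inhibition and higher numbers for weaker inhibition), compound 1 gives 21700 nM, and compound 2 gives 14600 nM; these two numbers lie within the scatter of each other. Compound 3 `COc1ccc(C(=O)/C=C/c2ccc3c(c2)B(O)OC3)c(OC)c1` carries methoxy in place of hydrogen on an aromatic carbon; in this assay compound 3 gives 86300 nM, so the step of a 4.0-fold higher number from compound 1 to compound 3 (0.60 log units; beyond the scatter) is beyond the scatter. The same structural change is made twice among the compounds shown. Compound 4 `COc1ccc(C(=O)/C=C/c2ccc3c(c2)B(O)OC3)cc1OC` has not been measured; it carries methoxy in place of hydrogen on an aromatic carbon. The two places are not the same word for word: in compound 3 the new methoxy is meta to a methoxy group, in compound 4 it is ortho to a methoxy group, so this is the same kind of change, not the same. For compound 4 in this assay a step of a 3.1-fold higher number from compound 2 to compound 4 (0.49 log units; beyond the scatter) is expected, resting on the earlier step of a 4.0-fold higher number from compound 1 to compound 3 (0.60 log units; beyond the scatter) and on compound 2 giving 14600 nM. Compound 4 is therefore estimated at 45000 nM, with an expected range from 15000 nM to 130000 nM.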

Compound 4, half-maximal inhibitory concentration: 33500 nM
For compound 4 the middle estimate is 1.3-fold (0.13 log units) above the measured one; low and high end bracket the measured number.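

In this assay the added methoxy again goes with a higher number, a 2.3-fold higher number from compound 2 to compound 4 (0.36 log units; beyond the scatter), so the direction seen on the core of compound 1 recurs on the core of compound 2. The two steps share that direction, and their sizes cannot be told apart: the same change on two cores in this assay, a 4.0-fold higher number (0.60 log units; beyond the scatter) from compound 1 to compound 3 and a 2.3-fold higher number (0.36 log units; beyond the scatter) from compound 2 to compound 4, 1.7-fold (0.24 log units) apart, within the scatter of two such steps. This rests on two pairs only, with the new methoxy not in the same place in each, so it shows that the change carried over between these two cores, but not that it would carry to other cores or other places, and it gives no cause for the shift.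

Open, on these data alone, is whether a group other than methoxy on that aromatic carbon, such as an ethoxy group, an amine or a carboxylic acid, would move the number in the same direction and by a similar size. Also open, as far as these compounds go, is whether the same step would appear in any read-out other than this assay.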